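A Second Chlorine in an Oxime Ether Series

The source may report more compounds than this note shows. Statements on the series, on what has been measured and on what is new or still open speak of the compounds shown alone.

Compound 1 `Clc1ccc(COc2ccc(/C=C/C(/C=C/c3ccccn3)=N/Oc3ncnc4ccccc34)cc2)cc1` is the reference point. In a functional assay on SMMC-7721 cells (Homo sapiens) for inhibition, read by MTT assay, with a stated time of 72 h, tested at 1 uM (a higher number here means a stronger effect of the compound at the concentration tested, a lower number a weaker effect), compound 1 gives 91.2%. Going by the values given here, compound 2 `Clc1ccc(COc2ccc(/C=C/C(/C=C/c3ccccn3)=N/Oc3ncnc4cc(Cl)ccc34)cc2)cc1` differs from it only by chloro in place of hydrogen on an aromatic carbon, and in this assay compound 2 gives 67.4%; the step of a number 23.8 percentage points lower from compound 1 to compound 2 (beyond the scatter) is the one measured example of this kind of change. Compound 3 `Cc1cccc2ncnc(O/N=C(\C=C\c3ccccn3)/C=C/c3ccccc3OCc3ccccc3Cl)c12` is built on a different core, and the difference between the two cores is not broken down here. In this assay compound 3 gives 86.8%, a value within the scatter of that of compound 1. Compound 4 `Cc1cccc2ncnc(O/N=C(\C=C\c3ccccn3)/C=C/c3ccccc3OCc3ccc(Cl)cc3Cl)c12`, still unmeasured, differs from compound 3 by chloro in place of hydrogen on an aromatic carbon. This is the same kind of change as that from compound 1 to compound 2, not the same: there the chloro entered a ring that is part of a fused system of two rings, meta and para to a fused ring, whereas here it enters a ring of carbon only, meta to a chloro group and para to a large group. Resting on the single step of a number 23.8 percentage points lower from compound 1 to compound 2 (beyond the scatter), but tempered by the different surroundings, the expected step is a number 11.8 percentage points lower from compound 3 to compound 4 (beyond the scatter), so compound 4 is estimated at 75%, likely between 55% and 92%.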

Compound 4, a percentage reported as inhibition, at one concentration (the size of the read-out at that concentration, not a potency): 90.8%
Compound 4: the middle estimate sits 15.8 percentage points below what was measured; measured number inside the range.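

In this assay, going from 2-chlorobenzyl to 2,4-dichlorobenzyl gives a number 4 percentage points higher from compound 3 to compound 4 (within the scatter), so the clear drop seen with the same kind of change on the core of compound 1 does not appear here. Set side by side, the two steps show that this swap of hydrogen for chloro cannot simply be carried from one core to the other in this series: the same change on two cores in this assay, a number 23.8 percentage points lower (beyond the scatter) from compound 1 to compound 2 and a number 4 percentage points higher (within the scatter) from compound 3 to compound 4, 27.8 percentage points apart, beyond the scatter of two such steps With only one pair per core, and with the chloro entering a different kind of ring in each pair, the data do not show whether the core, the ring that takes the chloro, or both decide the outcome.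

The compounds shown leave open what a chloro on the fused system of two rings would do in the core of compound 3, and what the same chloro on the carbon-only ring would do in the core of compound 1. They also leave open whether another group in place of the new chloro, such as a methoxy group or an amine, would follow either step.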